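The source may hold more compounds than are shown below. What is called first, only, known or untested is meant among the compounds shown, and "the series" means these compounds.

Measured compounds:
- compound 1 `CC(=O)c1cc(C(=O)c2ccccc2)c(=O)[nH]c1C` — 2%
- compound 2 `O=C1CCCc2[nH]c(=O)c(C(=O)c3ccccc3)cc21` — 0%
- compound 3 `CC(=O)c1cc(C(=O)C(C)(C)C)c(=O)[nH]c1C` — 1.15%

All three were run in an assay on isolated protein for inhibition of 3',5'-cyclic-AMP phosphodiesterase 4A (Cavia porcellus), read by cAMP accumulation, tested at 10 uM; on this read-out lower numbers stand for a weaker effect and higher numbers for a stronger effect at the one concentration tested. Compound 1 gives 2%, compound 2 gives 0% and compound 3 gives 1.15%; the three numbers lie within the scatter of one another, so no order among them can be read.

Compound 3 is compound 1 with tert-butyl in place of phenyl on a carbonyl carbon. That change made a number 0.9 percentage points lower from compound 1 to compound 3 (within the scatter). Compound 2 carries a different core from compound 1; the difference between the two cores is not broken down here.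

Compound 4 `CC(C)(C)C(=O)c1cc2c([nH]c1=O)CCCC2=O` has not yet been measured in this assay . It stands to compound 2 as compound 3 stands to compound 1: tert-butyl in place of phenyl on a carbonyl carbon, and the surroundings of the carbonyl carbon are the same in both cases, so the change is the same one, now on the core of compound 2.

Because the earlier step was a number 0.9 percentage points lower from compound 1 to compound 3 (within the scatter), and because compound 2 itself gives 0%, the step from compound 2 to compound 4 is expected to be small, a number 1 percentage points higher from compound 2 to compound 4 (within the scatter). Compound 4 is therefore estimated at 1%, most likely between -5% and 8%.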

Compound 4, a percentage reported as inhibition, at one concentration (the size of the read-out at that concentration, not a potency): 2.5%
Compound 4: the middle estimate sits 1.5 percentage points below what was measured; the range from low to high includes it.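

In this assay the new step for tert-butyl in place of phenyl on a carbonyl carbon is a number 2.5 percentage points higher from compound 2 to compound 4 (within the scatter), and it compares with the earlier step on the other core as follows: the same change on two cores in this assay, a number 0.9 percentage points lower (within the scatter) from compound 1 to compound 3 and a number 2.5 percentage points higher (within the scatter) from compound 2 to compound 4, 3.4 percentage points apart, within the scatter of two such steps. The change therefore carries between these two cores with no difference that can be read, but this agreement rests on four small numbers at one tested concentration and amounts to little more than neither core showing a clear response with either group. It does not show that the step would hold on a compound with a larger effect, nor does it give a potency for any of the four compounds.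

The compounds shown place only phenyl and tert-butyl on this carbonyl carbon, so it remains open whether a longer chain, an amine or a carboxylic acid there would give a clear effect. Going by these compounds, it also remains open whether any such effect would carry from one core to the other.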